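This account rests on a few compounds, and the source may have more. Where it says the series, first, only, none or still open, it means among the compounds named here.

compound 1: `Cc1cccc(F)c1N(C)C(=O)c1ccc(-c2ccc(O)cc2)o1`, in an assay on T47D cells for inhibition of 17-beta-hydroxysteroid dehydrogenase type 1 (Homo sapiens), read by HPLC, with a stated time of 24 h (on this read-out lower numbers stand for stronger inhibition and higher numbers for weaker inhibition), compound 1 gives 120 nM
compound 2: `Cc1c(F)cccc1N(C)C(=O)c1ccc(-c2ccc(O)cc2)o1`, in this assay compound 2 gives 50 nM

Within the data shown here, of the two numbers measured so far, compound 2 has the lowest; its nearest neighbour is compound 1, and the only measured step is a 2.4-fold lower number from compound 1 to compound 2 (0.38 log units; beyond the scatter). Compound 3 is `Cc1ccncc1N(C)C(=O)c1ccc(-c2ccc(O)cc2)o1`. The change from compound 2 to compound 3 is 4-methylpyridin-3-yl in place of 3-fluoro-2-methylphenyl on an amide-type nitrogen. Among the measured compounds shown here, the one measured step, from compound 1 to compound 2, moved the fluorine and the methyl around the same ring of carbon only and brought a modest gain; the step into compound 3 instead removes the fluorine and brings a ring nitrogen in, which no measured pair tests. The expectation is therefore a small step in this assay, if anything towards a higher number, which the estimate a 1.8-fold higher number from compound 2 to compound 3 (0.26 log units; within the scatter) expresses. Compound 3 is estimated to give 90 nM, expected to fall between 30 nM and 300 nM.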

Compound 3, half-maximal inhibitory concentration: 64 nM
Estimate against measurement, compound 3: 1.4-fold (0.15 log units) above; measured number inside the range.
By their numbers in this assay, from the lowest: compounds 2, 3 and 1 (each within the scatter of the next, the first and the last beyond it).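

On the amide-type nitrogen, the 4-methylpyridin-3-yl group, with a ring nitrogen and no fluorine, is tolerated in this assay: replacing the 3-fluoro-2-methylphenyl group gives a 1.3-fold higher number from compound 2 to compound 3 (0.11 log units; within the scatter), and replacing the 2-fluoro-6-methylphenyl group gives a 1.9-fold lower number from compound 1 to compound 3 (0.27 log units; within the scatter). Until now this position had been probed only with rings of carbon alone bearing fluorine and methyl, and compound 3 shows that neither feature is required for a reading within the scatter of both earlier compounds, even though those two lie beyond the scatter of each other. Nothing measured here explains this result.

The compounds shown do not separate the effect of bringing in the ring nitrogen from that of removing the fluorine. They also do not show how this assay would respond to an amine or a carboxylic acid in place of the methyl on the pyridine ring.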